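This account rests on a few compounds, and the source may have more. Where it says the series, first, only, none or still open, it means among the compounds named here.

Measured so far:
- compound 1 `COc1ccc(-c2nn(-c3ccc(F)cc3F)cc2CNCCN2CCN(C)CC2)cc1`. In an ADME assay on Huh-7 cells (Homo sapiens) for cytotoxicity (a lower number here means that less compound is tolerated, a higher number that more compound is tolerated), compound 1 gives > 20000 nM, which is a limit of the assay and not a number.
- compound 2 `CN1CCN(CCNCc2cn(-c3ccc(F)cc3F)nc2-c2ccc(C(F)(F)F)cc2)CC1`. In this assay compound 2 gives 20000 nM.

Compound 2 holds the only actual number shown in this assay; the one further value is the limit recorded for compound 1. On these data alone, the step from compound 1 to compound 2, trifluoromethyl in place of methoxy on an aromatic carbon, reads a number no higher from compound 1 to compound 2 (the limit leaves the size open), and its size stays open because of the limit of > 20000 nM in this assay, at which 1 of the 2 values shown sits.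

Compound 3 `CN1CCN(CCNCc2cn(-c3ccc(F)cc3F)nc2-c2ccc(Cl)cc2)CC1` differs from compound 2 by chloro in place of trifluoromethyl on an aromatic carbon. For the measured compounds named here, no measured step exchanges trifluoromethyl for chloro; the only step touches the same aromatic carbon, and its size cannot be read. On that footing no step beyond the scatter is expected in this assay in either direction, and a limit rather than a number remains possible. Compound 3 is therefore expected to give 20000 nM, with a range from 10000 nM to 40000 nM. The expected step from compound 2 to compound 3 is no change at the digits printed from compound 2 to compound 3 (within the scatter), that is, none beyond the scatter.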

Compound 3, half-maximal cytotoxic concentration: 19000 nM
Compound 3: the middle estimate sits 1.1-fold (0.02 log units) above what was measured, within the range that was stated.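

In this assay, for the compounds shown here, the exchange of 4-(trifluoromethyl)phenyl for 4-chlorophenyl gives the first step of readable size at this aromatic carbon, para to a large group: a 1.1-fold lower number from compound 2 to compound 3 (0.02 log units; within the scatter). Chloro, with 1 heavy atom, therefore takes the place of trifluoromethyl, with 4 heavy atoms, without a change beyond the scatter between two actual numbers. The comparison with methoxy reads an at least 1.0-fold lower number from compound 1 to compound 3 (0.02 log units; that floor lies within the scatter), but it has only a floor and its full size stays open because compound 1 carries a limit of the assay and not a number: the limit of > 20000 nM in this assay, at which 1 of the 3 values shown sits.

On these data alone, whether an amine or a carboxylic acid on this aromatic carbon would shift the number beyond the scatter remains open. Also open, as far as these compounds go, is whether a longer chain elsewhere on the shared core would matter more in this assay than any exchange at this carbon.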